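A few compounds are considered here, and "the series" means these few. Any claim that something is new, unique, unknown or untested is made for them only; others in the source may bear on it.

Measured so far in a functional assay on HepG2 cells (Homo sapiens) for antiproliferative activity, read by MTT assay; on this read-out higher numbers stand for weaker inhibition and lower numbers for stronger inhibition
- compound 1 `COc1ccc(-c2ccnc(Nc3ccc([N+](=O)[O-])cc3)n2)cc1` at 1040 nM
- compound 2 `Cc1cccc(Nc2nccc(-c3ccc(Br)cc3)n2)c1` at 74600 nM
- compound 3 `COc1ccc(-c2ccnc(Nc3ccc(Cl)cc3Cl)n2)cc1` at 190 nM

In this assay compound 3 at 190 nM stands lowest of the three, and the numbers of compound 1 and compound 2 both lie above it beyond the scatter. Compound 4 `Clc1ccc(Nc2nccc(-c3ccc(Br)cc3)n2)c(Cl)c1` is not yet measured. The change bromo in place of methoxy on an aromatic carbon is bromo in place of methoxy on an aromatic carbon, para to a large group. Going by the values given here, no measured pair shows this change alone. Among the compounds with values here, the only guide is compound 2 at 74600 nM as the sole measured bromo compound, whose number is higher than those of the two methoxy compounds, compound 1 and compound 3. That compound also differs from compound 3 elsewhere, so only part of its gap is carried over. The estimated step of a 7.9-fold higher number from compound 3 to compound 4 (0.90 log units; beyond the scatter) is therefore a rise in the number, moderate but beyond the scatter. Compound 4 is expected at 1500 nM within a range of 200 nM to 12000 nM by this estimate.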

Compound 4, half-maximal inhibitory concentration: 720 nM
For compound 4 the middle estimate is 2.1-fold (0.32 log units) above the measured one; the range from low to high includes it.
By their numbers in this assay, from the lowest: compound 3; then compounds 4 and 1 (each within the scatter of the next); then compound 2.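

In this assay, bromo in place of methoxy on an aromatic carbon, para to a large group, can now be read as a single change: it gives a 3.8-fold higher number from compound 3 to compound 4 (0.58 log units; beyond the scatter). Methoxy therefore holds a real but modest advantage over bromo at this position, and the position does not depend on methoxy for a measurable effect, something compound 2 could not show because it differs from the methoxy compounds in more than one place. Nothing available accounts for the rise in the number.

Still open, on these data alone, is how other groups at this position compare, such as a hydroxyl, an amine, a carboxylic acid or a longer alkoxy chain. Also open, as far as these compounds go, is whether this change gives a similar step when the rest of the molecule differs, as it does in compound 1.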